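The compounds below may be only part of what the source reports. "The series", "measured", "known", "first", "only" and "open" are said of these compounds alone.

Measured so far:
Compound 1 `[O-][S+](Cc1ccccc1)c1nnc(-c2ccncc2)o1` gives 4000 nM
Compound 2 `[O-][S+](Cc1ccccc1)c1nnc(-c2cccnc2)o1` gives 8000 nM

In a functional assay on HUVEC cells (Homo sapiens) for inhibition, read by ELISA (on this read-out lower numbers stand for stronger inhibition and higher numbers for weaker inhibition), compound 2 gives 8000 nM and lies within the scatter of compound 1. Compound 3 `[O-][S+](Cc1ccccc1)c1nnc(-c2ccccn2)o1` carries pyridin-2-yl in place of pyridin-3-yl on an aromatic carbon, and pyridin-2-yl in place of pyridin-3-yl on an aromatic carbon sets out the difference. Among the compounds with values here, the one measured step that bears on this is a 2.0-fold higher number from compound 1 to compound 2 (0.30 log units; within the scatter) for pyridin-3-yl in place of pyridin-4-yl, and it stays within the scatter. No change beyond the scatter is therefore expected in this assay and no firm direction can be given. The expected step is a 1.3-fold lower number from compound 2 to compound 3 (0.12 log units; within the scatter) and it stays within the scatter. The estimate for compound 3 is 6000 nM with 2000 nM to 20000 nM as its range.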

Compound 3, half-maximal inhibitory concentration: 5000 nM
Beside the measured number, compound 3's estimate is 1.2-fold (0.08 log units) above it; the range from low to high includes it.
By their numbers in this assay, from the lowest: compounds 1, 3 and 2 (each within the scatter of the next).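

In this assay, pyridin-2-yl in place of pyridin-3-yl gives a 1.6-fold lower number from compound 2 to compound 3 (0.20 log units; within the scatter), and pyridin-2-yl in place of pyridin-4-yl gives a 1.3-fold higher number from compound 1 to compound 3 (0.10 log units; within the scatter). With pyridin-2-yl added, all three pyridine attachments on this aromatic carbon lie within the scatter of one another, so moving the ring nitrogen around this group separates none of the compounds shown. No evidence at hand bears on this result. The compounds shown leave open whether a phenyl, an amine or a carboxylic acid on this carbon would move the number beyond the scatter.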